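Dropping One Trifluoromethyl From the Strongest Compound

This account rests on a few compounds, and the source may have more. Where it says the series, first, only, none or still open, it means among the compounds named here.

Measured so far in a functional assay on OVCAR-8 cells (Homo sapiens) for inhibition, read by sulforhodamine B assay, with a stated time of 48 h, tested at 1 uM; on this read-out higher numbers stand for a weaker effect at the one concentration tested and lower numbers for a stronger effect:
compound 1 `O=C(Nc1cccc(-n2cc(-c3ccncc3)c(-c3cc(O)cc(Cl)c3)n2)c1)Nc1ccc(Cl)c(C(F)(F)F)c1`: 99%
compound 2 `O=C(Nc1cccc(-n2cc(-c3ccncc3)c(-c3cc(O)cc(Cl)c3)n2)c1)Nc1ccc(Cl)c(Cl)c1`: 56%
compound 3 `COc1cc(Cl)cc(-c2nn(-c3cccc(NC(=O)Nc4cc(C(F)(F)F)cc(C(F)(F)F)c4)c3)cc2-c2ccncc2)c1`: 12%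

Compound 3 stands lowest of the three numbers in this assay, and therefore strongest at the single concentration; compound 2 is nearest to it and compound 1 furthest, both gaps beyond the scatter. The next compound, compound 4 `COc1cc(Cl)cc(-c2nn(-c3cccc(NC(=O)Nc4cccc(C(F)(F)F)c4)c3)cc2-c2ccncc2)c1`, differs from compound 3 in one place: hydrogen in place of trifluoromethyl on an aromatic carbon.

For the measured compounds named here, only one measured step changes a group on the same aromatic carbon, a number 43 percentage points lower from compound 1 to compound 2 (beyond the scatter), but there chloro entered rather than hydrogen, and the two compounds carry a hydroxy group where compound 3 and compound 4 carry methoxy, so that step bears on the present change only loosely. It shows that a single change at this position can move the number a long way. With no measured case of a trifluoromethyl simply removed, compound 4 is expected to lose some of the effect of compound 3, a step of a number 23 percentage points higher from compound 3 to compound 4 (beyond the scatter) upward, with wide uncertainty. The estimate for compound 4 in this assay is 35%, within 10% to 70%.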

Compound 4, a percentage reported as activity, at one concentration (the size of the read-out at that concentration, not a potency): 54%
Compound 4: middle estimate off by 19 percentage points, on the low side; measured number inside the range.
By their numbers in this assay, from the lowest: compound 3; then compounds 4 and 2 (each within the scatter of the next); then compound 1.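

In this assay, the removal of one trifluoromethyl, with hydrogen entering on the aromatic carbon, gives a number 42 percentage points higher from compound 3 to compound 4 (beyond the scatter), the first measured case of this group simply taken away. The step shows that this trifluoromethyl counts for much of the effect at the one concentration tested, even though the other trifluoromethyl stays on the ring, and that the earlier step of a number 43 percentage points lower from compound 1 to compound 2 (beyond the scatter), which ran the other way, does not set a single direction for replacing a trifluoromethyl, although those two compounds also differ from compound 3 and compound 4 in their other groups. Nothing available explains why the number moves so far at this position.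

The compounds shown leave open whether a methyl or a nitrile on this aromatic carbon would keep the number near that of compound 3 at 12% or behave as hydrogen does. They also leave open whether taking away this trifluoromethyl would move the number as far in compounds that carry hydroxy in place of methoxy.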